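Trimethylphenyl for dichlorophenyl in a weakly active series

This account rests on a few compounds, and the source may have more. Where it says the series, first, only, none or still open, it means among the compounds named here.

In a functional assay on HeLa cells (Homo sapiens) for inhibition, read by MTT assay, with a stated time of 48 h (a lower number here means a stronger inhibitor, a higher number a weaker inhibitor), compound 1 `O=C(CC(c1ccc(Cl)cc1)C(C(=O)Nc1ccccn1)C(=O)Nc1ccccn1)c1ccccc1` gives 13600 nM and compound 2 `O=C(CC(c1ccc([N+](=O)[O-])cc1)C(C(=O)Nc1ccccn1)C(=O)Nc1ccccn1)c1ccccc1` gives 30000 nM on the same core. Going by the values given here, compound 3 `O=C(CC(c1c(Cl)cccc1Cl)C(C(=O)Nc1ccccn1)C(=O)Nc1ccccn1)c1ccccc1` is reported as "not active" (no number reported) and carries no number, so no step can be sized from it.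

Compound 4 `Cc1cc(C)c(C(CC(=O)c2ccccc2)C(C(=O)Nc2ccccn2)C(=O)Nc2ccccn2)c(C)c1` differs from compound 3 in one place, on a saturated chain carbon bound to two saturated chain carbons: 2,4,6-trimethylphenyl in place of 2,6-dichlorophenyl on a saturated chain carbon bound to two saturated chain carbons with 2,4,6-trimethylphenyl in place of 2,6-dichlorophenyl.

Among the compounds with values here, the only measured step is a 2.2-fold higher number from compound 1 to compound 2 (0.34 log units; beyond the scatter) and it is modest. It swaps a different pair of groups, so it bears on this change only loosely. Within the data shown here, no size of step from compound 3 can therefore be stated. The expectation is that activity stays weak, and a second report without a number remains a real possibility. Compound 4 is estimated at 40000 nM with an expected range of 15000 nM to 100000 nM if a number is obtained.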

Compound 4, half-maximal inhibitory concentration: 15100 nM
For compound 4 the middle estimate is 2.6-fold (0.42 log units) above the measured one; measured number inside the range.
By their numbers in this assay, from the lowest: compounds 1, 4 and 2 (each within the scatter of the next, the first and the last beyond it).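

In this assay, the position on a saturated chain carbon bound to two saturated chain carbons now yields a number with 2,4,6-trimethylphenyl, whereas compound 3, with 2,6-dichlorophenyl, was reported as not active, so the step between those two compounds cannot be read. The new number does not separate 2,4,6-trimethylphenyl from either 4-nitrophenyl (a 2.0-fold lower number from compound 2 to compound 4 (0.30 log units; within the scatter)) or 4-chlorophenyl (a 1.1-fold higher number from compound 1 to compound 4 (0.05 log units; within the scatter)), so the series remains weakly active across these three groups. No measured evidence explains why compound 4 gives a number and compound 3 does not.

Going by these compounds, how an unsubstituted phenyl, 4-methoxyphenyl or benzyl group would read at this position remains open. Also open, on these data alone, is whether any group here, or a change elsewhere on the shared core, could give a number clearly lower than those of compounds 1, 2 and 4.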